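A methoxy removed, with the outcome still open

A few compounds are considered here, and "the series" means these few. Any claim that something is new, unique, unknown or untested is made for them only; others in the source may bear on it.

Compound 1 `O=C(Nc1ccc(OC(F)(F)F)cc1)c1cc(F)ccc1O` and compound 2 `N#Cc1ccc(NC(=O)c2ccc3cccnc3c2O)c(Cl)c1` are the two compounds of this set that return numbers. In a functional assay on HL-60 cells (Homo sapiens) for cytotoxicity, read by luminescence and CellTiter-Glo, with a stated time of 3 days (on this read-out higher numbers stand for weaker inhibition and lower numbers for stronger inhibition), compound 1 gives 850 nM, and compound 2 gives 910 nM; the two values lie within the usual scatter of each other, so neither can be called the stronger. Compound 3 `COc1ccc(O)c(C(=O)Nc2ccc(C#N)cc2)c1` stands apart. In this assay compound 3 gives only a limit, > 10000 nM, and not a number. For compound 3 this is the limit of > 10000 nM in this assay, at which 1 of the 3 values shown sits.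

Compound 4 `N#Cc1ccc(NC(=O)c2ccccc2O)cc1` has not been measured. Compound 4 differs from compound 3 by hydrogen in place of methoxy on an aromatic carbon. Among the compounds with values here, no step between measured compounds is known here that would show what this change does, and compound 3 itself provides only a limit to start from. The step expected in this assay is therefore modest, an at least 1.2-fold lower number from compound 3 to compound 4 (0.09 log units; that floor lies within the scatter), and may again end in a limit rather than a number. Compound 4 is expected to give 8000 nM, somewhere between 2000 nM and 30000 nM.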

Compound 4, half-maximal inhibitory concentration: 4620 nM
Estimate against measurement, compound 4: 1.7-fold (0.24 log units) above; the measured number falls inside the stated range.
By their numbers in this assay, from the lowest: compounds 1 and 2 (each within the scatter of the next); then compound 4. At a limit, above all of these: compound 3.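

In this assay, hydrogen in place of methoxy, on the aromatic carbon para to a hydroxy group, gives an at least 2.1-fold lower number from compound 3 to compound 4 (0.33 log units; beyond the scatter). Within the data shown here, this is the first step in the set that can be read at this position, and it lies beyond the scatter, so the methoxy of compound 3 does not pass without consequence for this read-out. The size of the step is only a floor, because compound 3 stands at a limit and not at a number: the limit of > 10000 nM in this assay, at which 1 of the 4 values shown sits.

The compounds shown leave open whether the higher number belongs to methoxy alone or would also come with another group on this carbon, such as an amine or a carboxylic acid. Going by these compounds, compound 1 and compound 2 differ from compound 4 in more than one place, so it also remains open whether this step would hold on another core.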